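From a carbamoylphenyl to a fluorophenyl on the ring amine

The source may hold more compounds than are shown below. What is called first, only, known or untested is meant among the compounds shown, and "the series" means these compounds.

Four compounds of one series are followed in a functional assay on HL-60 cells (Homo sapiens) for inhibition, read by MTT assay, with a stated time of 72 h; on this read-out higher numbers stand for weaker inhibition and lower numbers for stronger inhibition. Compound 1 `O=C(c1oc(C(F)(F)F)nc1-c1cccc(F)c1)N1CCN(c2cccc(Cl)c2)CC1` is reported as "not active" (no number reported). Compound 2 `Cc1nc(-c2ccccc2)c(C(=O)N2CCN(c3cccc(C(N)=O)c3)CC2)o1` gives 71 nM, the lowest of the two numbers in hand, while compound 3 `COc1ccc(Cl)cc1N1CCN(C(=O)c2oc(C)nc2-c2ccccc2F)CC1` gives 153 nM, a gap beyond the scatter. Compound 4 `Cc1nc(-c2ccccc2)c(C(=O)N2CCN(c3ccccc3F)CC2)o1` is not yet measured; it differs from compound 2 in one place: 2-fluorophenyl in place of 3-carbamoylphenyl on an amine nitrogen in a ring. Among the compounds with values here, no measured pair shows this exact change, so compound 2 alone anchors the expectation. The carbamoyl group of compound 2 is lost, and compound 3, which carries no such group, stands higher. A modest step toward weaker inhibition is expected, a 2.8-fold higher number from compound 2 to compound 4 (0.45 log units; beyond the scatter). Compound 4 is thus estimated at 200 nM, within a range from 60 nM to 800 nM.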

Compound 4, half-maximal inhibitory concentration: 147 nM
Compound 4: middle estimate off by 1.4-fold (0.13 log units), on the high side; the range from low to high includes it.
By their numbers in this assay, from the lowest: compound 2; then compounds 4 and 3 (each within the scatter of the next).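

In this assay the exchange of 3-carbamoylphenyl for 2-fluorophenyl on the amine nitrogen in the ring gives a 2.1-fold higher number from compound 2 to compound 4 (0.32 log units; beyond the scatter). Inhibition therefore remains without the carbamoyl group at this position, so that group is not required, although compound 2 keeps the lower number. Nothing available here explains the size of this step.

The change also moves the substituent and swaps its kind, so these two contributions stay unseparated. A plain phenyl, a 3-fluorophenyl or a 2-carbamoylphenyl on this nitrogen would bear on that question.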